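Half-life of a Sulfanyl Sulfonylguanidine Series after a Benzyl Swap

The source may hold more compounds than are shown below. What is called first, only, known or untested is meant among the compounds shown, and "the series" means these compounds.

Measured compounds:
- Compound 1 `Cc1cc(S(=O)(=O)/N=C(\N)n2nccc2-c2ccccc2)c(SCc2ccccc2Cl)cc1Cl` gives 0.226 h in an ADME assay on microsomes from liver (Homo sapiens) for metabolic stability, read by LC-MS, using NADPH, tested at 5 uM; on this read-out higher numbers stand for a longer-lived compound and lower numbers for a shorter-lived compound.
- Compound 2 `Cc1cc(-c2ccccc2)n(/C(N)=N/S(=O)(=O)c2cc(C)c(Cl)cc2SCc2ccccc2C)n1` gives 0.154 h in this assay.
- Compound 3 `Cc1cccc(CSc2cc(Cl)c(C)cc2S(=O)(=O)/N=C(\N)n2nccc2-c2ccccc2)c1` gives 0.232 h in this assay.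

Compound 3 stands at the highest of the three numbers in this assay, yet its nearest neighbour compound 1 is within the scatter of it, and even compound 2, the furthest, lies within the scatter. Compound 4 `Cc1cc(S(=O)(=O)/N=C(\N)n2nccc2-c2ccccc2)c(SCc2ccccc2C)cc1Cl` differs from compound 3 in one place: 2-methylphenyl in place of 3-methylphenyl on a saturated chain carbon bound to a sulfur. Among the compounds with values here, the only measured step touching this position is a 1.0-fold higher number from compound 1 to compound 3 (0.01 log units; within the scatter), which shows that exchanging one benzyl aryl group for another left the half-life essentially unchanged. Compound 2 carries the same 2-methylphenyl group on a different core, and its value and that of compound 3 are within the scatter of each other. On this basis compound 4 is expected to show a step of a 1.1-fold lower number from compound 3 to compound 4 (0.04 log units; within the scatter), meaning no change beyond the scatter. Compound 4 is therefore estimated at 0.21 h, within a range from 0.11 h to 0.4 h.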

Compound 4, half-life: 0.0802 h
Estimate against measurement, compound 4: 2.6-fold (0.42 log units) above; the measured number lies below the stated range.
By their numbers in this assay, from the lowest: compounds 4, 2, 1 and 3 (each within the scatter of the next, the first and the last beyond it).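

In this assay the place of the methyl on the benzyl group proves not to be neutral: 2-methylphenyl in place of 3-methylphenyl on a saturated chain carbon bound to a sulfur gives a 2.9-fold lower number from compound 3 to compound 4 (0.46 log units; beyond the scatter) and so shortens the half-life. The earlier exchange, with a 1.0-fold higher number from compound 1 to compound 3 (0.01 log units; within the scatter) within the scatter, had suggested that this aryl group could vary freely, yet methyl in place of chloro on an aromatic carbon gives a 2.8-fold lower number from compound 1 to compound 4 (0.45 log units; beyond the scatter) and shows that it cannot. Hydrogen in place of methyl on an aromatic carbon of the core gives a 1.9-fold lower number from compound 2 to compound 4 (0.28 log units; within the scatter) within the scatter, so no effect of that change can be read.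

Nothing shown here explains the shorter half-life of compound 4. As far as these compounds go, it also remains open how a 2-methoxyphenyl or an unsubstituted phenyl group on the same chain carbon would compare.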